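Ring-nitrogen substituent exchange in a small series

A few compounds are considered here, and "the series" means these few. Any claim that something is new, unique, unknown or untested is made for them only; others in the source may bear on it.

Of the compounds shown here, two have numbers so far. In a functional assay on NCI-H1975 cells (Homo sapiens) for inhibition, read by sulforhodamine B assay, tested at 10 uM (a lower number here means less inhibition, a higher number more inhibition at the concentration tested (going by the name of the read-out)), compound 1 `CN(C)c1ccc(C2CC(c3ccc(-n4ccnc4)cc3)=NN2)cc1` gives 0.1%. In this assay compound 2 `Cc1ccc(C(=O)N2N=C(c3ccc(N4CCN(C)CC4)cc3)CC2c2ccc(N(C)C)cc2)cc1` gives -0.4%; this is the lowest of the two numbers, but compound 1 lies within the scatter of it, so neither compound shows inhibition at the concentration tested. Compound 3 `CN1CCN(c2ccc(C3=NN(S(C)(=O)=O)C(c4ccc(N(C)C)cc4)C3)cc2)CC1` has not been measured; it differs from compound 2 as follows: methylsulfonyl in place of (4-methylphenyl)carbonyl on an amine nitrogen in a ring. Going by the values given here, no step between measured compounds is available, and the two numbers show no inhibition to build on. The step expected a number 1.4 percentage points higher from compound 2 to compound 3 (within the scatter) is none beyond the scatter. Compound 3 is estimated at 1%, with a range from -10% to 14%.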

Compound 3, a percentage reported as inhibition, at one concentration (the size of the read-out at that concentration, not a potency): -1.3%
Compound 3: middle estimate off by 2.3 percentage points, on the high side; the range from low to high includes it.
By their numbers in this assay, from the lowest: compounds 3, 2 and 1 (each within the scatter of the next).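

Methylsulfonyl in place of (4-methylphenyl)carbonyl on the amine nitrogen in the ring gives a number 0.9 percentage points lower from compound 2 to compound 3 (within the scatter) in this assay. At this position, then, removing the six-membered aromatic ring of the substituent does not separate the two compounds, and neither substituent gives a number that stands out from the scatter. No available measurement bears on why these compounds do not differ.

Still open, going by these compounds, is whether an amine or a carboxylic acid on the benzoyl ring, or a longer chain in place of the sulfonyl methyl, would produce inhibition at this position.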